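The source may hold more compounds than are shown below. What is called first, only, known or untested is meant among the compounds shown, and "the series" means these compounds.

Three compounds that share one core were tested in a functional assay on U-87MG ATCC cells for inhibition, with U-87 MG (Homo sapiens) as the target, read by MTT assay, with a stated time of 72 h; on this read-out higher numbers stand for weaker inhibition and lower numbers for stronger inhibition. Compound 1 `C=C[C@]1(C)C[C@@H](OC(=O)CNC(=O)Nc2ccc(Cl)cc2)[C@]2(C)[C@H](C)CC[C@]3(CCC(=O)[C@H]32)[C@@H](C)[C@@H]1O` carries a 4-chlorophenyl on an amide-type nitrogen; in this assay compound 1 gives > 10000 nM, which is a limit of the assay rather than a number. Compound 2 `C=C[C@]1(C)C[C@@H](OC(=O)CNC(=O)NC(=O)c2cccc(F)c2)[C@]2(C)[C@H](C)CC[C@]3(CCC(=O)[C@H]32)[C@@H](C)[C@@H]1O` bears a (3-fluorophenyl)carbonyl on that nitrogen, and in this assay compound 2 gives > 10000 nM, again a limit. Compound 3 `C=C[C@]1(C)C[C@@H](OC(=O)CNC(=O)Nc2ccc(F)cc2)[C@]2(C)[C@H](C)CC[C@]3(CCC(=O)[C@H]32)[C@@H](C)[C@@H]1O` carries a 4-fluorophenyl, and in this assay compound 3 gives > 10000 nM, once more a limit. Because all three values sit at the same limit (the limit of > 10000 nM in this assay, at which 3 of the 3 values shown sit), none of the steps among them can be read: a step that the two limits leave unreadable from compound 1 to compound 2, a step that the two limits leave unreadable from compound 1 to compound 3 and a step that the two limits leave unreadable from compound 2 to compound 3 are all unreadable. Compound 2 therefore stands at the limit, level with its two neighbours as far as the numbers show.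

Compound 4 `C=C[C@]1(C)C[C@@H](OC(=O)CNC(=O)Nc2ccc(F)cc2F)[C@]2(C)[C@H](C)CC[C@]3(CCC(=O)[C@H]32)[C@@H](C)[C@@H]1O` differs from compound 2 in one place: 2,4-difluorophenyl in place of (3-fluorophenyl)carbonyl on an amide-type nitrogen. The closest measured comparisons are the steps to compound 1 and to compound 3, which also exchange the (3-fluorophenyl)carbonyl for a halogen-bearing phenyl and which ended at the limit. Within the data shown here, no step of readable size bears on this change, so no shift beyond the scatter is expected in this assay, and another limit is the most likely outcome. Compound 4 is expected to give about 15000 nM in this assay, between 8000 nM and 50000 nM. The expected step that the limit leaves unreadable from compound 2 to compound 4 is accordingly small.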

Compound 4, half-maximal inhibitory concentration: > 10000 nM
Compound 4: only a limit was reported; the forecaster's own chance of this, stated with the estimate: 85%; the middle value does not contradict the limit.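

No step from compound 4 to compound 1, compound 2 or compound 3 can be read, since all four compounds give a limit rather than a number: the limit of > 10000 nM in this assay, at which 4 of the 4 values shown sit.

The compounds shown leave open whether the 4-chlorophenyl, (3-fluorophenyl)carbonyl, 4-fluorophenyl and 2,4-difluorophenyl groups on the amide-type nitrogen differ at all in inhibition.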